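The source may hold more compounds than are shown below. What is called first, only, known or untested is meant among the compounds shown, and "the series" means these compounds.

Of the compounds shown here, two built on a shared core have been measured so far. Compound 1 `CN(C)CCN1CCN(CC(=O)Nc2ccc(-c3nc4ccccc4o3)cc2)CC1` carries a longer chain on the amide, and in a functional assay on MCF7 cells (Homo sapiens) for cytotoxicity, read by MTT assay, with a stated time of 24 h (on this read-out lower numbers stand for stronger inhibition and higher numbers for weaker inhibition), compound 1 gives 59400 nM. Compound 2 `Cc1cc(-c2nc3ccccc3o2)ccc1NC(=O)CCl` carries a chloroacetamide instead, and in this assay compound 2 gives 29800 nM. Of the two numbers, that of compound 2 is the lower one, but the two values lie within the scatter of each other, so nothing can be said about an order between them.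

Compound 3 `Cc1ccc2oc(-c3ccc(NC(=O)CCl)c(C)c3)nc2c1` has not been measured yet. It differs from compound 2 in one place: methyl in place of hydrogen on an aromatic carbon. Going by the values given here, no pair of measured compounds shows what such a change does on this core, so there is no measured step to lean on. With only one heavy atom entering, the expectation is that the step from compound 2 to compound 3 will not reach beyond the scatter, and a 1.1-fold lower number from compound 2 to compound 3 (0.03 log units; within the scatter) is the step that the estimate implies. Compound 3 is therefore expected to give about 28000 nM, with a range from 10000 nM to 80000 nM.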

Compound 3, half-maximal inhibitory concentration: 96500 nM
Estimate against measurement, compound 3: 3.4-fold (0.54 log units) below; the whole stated range lies below it.
By their numbers in this assay, from the lowest: compounds 2, 1 and 3 (each within the scatter of the next, the first and the last beyond it).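

In this assay, placing methyl on an aromatic carbon of a six-membered aromatic ring of carbon only, part of a fused or bridged system of two rings, gives a 3.2-fold higher number from compound 2 to compound 3 (0.51 log units; beyond the scatter) and so moves the number beyond the scatter. Going by these compounds alone, this is the first change on the shared core that can be read on its own, since compound 1 and compound 2 differ in more than one place, and it shows that this position does not tolerate every small addition without a loss of inhibition in the cells. No measurement at hand explains the step.

Going by these compounds, whether the loss belongs to methyl alone or to any group at this carbon stays open, as a chlorine atom, a methoxy group, an amine or a carboxylic acid at the same place could move the number differently or not at all. On these data alone, it also remains unknown whether methyl on this carbon would have a similar effect with the longer chain of compound 1 on the amide, or whether the step holds only with the chloroacetamide.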